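This account rests on a few compounds, and the source may have more. Where it says the series, first, only, none or still open, it means among the compounds named here.

Measured compounds in the series:
compound 1, `Cc1ccc(NC(=S)N/N=C2\C(=O)N(Cc3ccc(F)cc3)c3ccc(Br)cc32)cc1` — 132000 nM
compound 2, `Cc1ccc(NC(=S)N/N=C2\C(=O)N(Cc3ccc(Cl)cc3)c3ccc(Br)cc32)cc1` — >= 500000 nM

Among the compounds with values here, compound 1 is the only member with a full number. In a functional assay on CCRF-CEM cells (Homo sapiens), with a stated time of 72 h (a higher number here means a weaker inhibitor, a lower number a stronger inhibitor), compound 1 gives 132000 nM. Compound 2 differs from it by chloro in place of fluoro on an aromatic carbon. In this assay compound 2 reaches only a limit, >= 500000 nM, which is a limit of the assay and not a number. Within the data shown here, the single measured step, an at least 3.7-fold higher number from compound 1 to compound 2 (0.57 log units; beyond the scatter), is therefore known only as a lower bound on its size, and compound 2 stands at the limit of >= 500000 nM in this assay, at which 1 of the 2 values shown sits.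

Compound 3 `Cc1ccc(CN2C(=O)/C(=N\NC(=S)Nc3ccc(C)cc3)c3cc(Br)ccc32)cc1` differs from compound 2 by methyl in place of chloro on an aromatic carbon. Among the measured compounds shown here, no measured step covers methyl in place of chloro; the one step available concerns fluoro to chloro, and it leaves compound 2 at the limit. The expectation for compound 3 can rest only on compound 2 sitting at the limit and on compound 1 being the sole point below it. Compound 3 is expected near 300000 nM, with a range from 100000 nM to 600000 nM. The step of an at least 1.6-fold lower number from compound 2 to compound 3 (0.22 log units; that floor lies within the scatter) is expected to be modest at most and may again end in a limit.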

Compound 3, half-maximal inhibitory concentration: >= 500000 nM
Compound 3: only a limit was reported (the forecaster's own chance of this, stated with the estimate: 50%); at least 1.6-fold (0.22 log units) between middle value and limit.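

Methyl in place of fluoro at this place, para to a large group, gives an at least 3.7-fold higher number from compound 1 to compound 3 (0.57 log units; beyond the scatter), so the move away from fluoro is now seen with a second group and not with chloro alone. In this assay compound 3 gives >= 500000 nM, which is a limit of the assay and not a number. The step between compound 2 and compound 3 cannot be read, so chloro and methyl cannot be ordered, and among the three compounds only the 4-fluorobenzyl member, compound 1, keeps a full number, with the series otherwise resting at one value: the limit of >= 500000 nM in this assay, at which 2 of the 3 values shown sit.

Going by these compounds, it remains open whether a full number at this place belongs to fluoro alone or would also appear with plain hydrogen, a methoxy group, an amine or a carboxylic acid. With only one full number in the series, the compounds shown also give no measured size for any change at this place, only lower bounds, and they say nothing about changes elsewhere on the shared core.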